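Benzamido in place of a pyrazolylethoxy group on the shared core

A few compounds are considered here, and "the series" means these few. Any claim that something is new, unique, unknown or untested is made for them only; others in the source may bear on it.

In a functional assay on HEK293 cells for agonist activity at G-protein coupled receptor 39 (Homo sapiens), read by scintillation proximity assay and inositol phosphate accumulation, with a stated time of 75 min (a lower number here means that less compound is needed, a higher number that more compound is needed for the effect), three compounds of the shared core have been measured. Compound 1 `Cc1nn(-c2ncnc3nc[nH]c23)c2c1C(OC1CCCC1)CC(=O)N2` gives 62 nM, compound 2 `Cc1nn(-c2ncnc3nc[nH]c23)c2c1C(C(=O)NCc1ccccc1)CC(=O)N2` gives 2930 nM, and compound 3 `Cc1nn(-c2ncnc3nc[nH]c23)c2c1C(OCCn1nccc1C)CC(=O)N2` gives 1620 nM. Compound 3 thus stands second highest of the three: its nearest neighbour is compound 2, from which the step of a 1.8-fold lower number from compound 2 to compound 3 (0.26 log units; within the scatter) lies within the scatter, while the step of a 26-fold higher number from compound 1 to compound 3 (1.42 log units; beyond the scatter) is large and beyond it.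

Compound 4 `Cc1nn(-c2ncnc3nc[nH]c23)c2c1C(NC(=O)c1ccccc1)CC(=O)N2` is not yet measured. Relative to compound 3 the change is a group of 9 heavy atoms (7 carbon, 1 nitrogen, 1 oxygen; one six-membered aromatic ring of carbon only) in place of a group of 9 heavy atoms (6 carbon, 2 nitrogen, 1 oxygen; one five-membered aromatic ring with 2 hetero atoms), on a saturated ring carbon. For the measured compounds named here, the step that bears on it is the one from compound 2 to compound 3, where a benzyl-bearing amide gave way to the pyrazolylethoxy group and the number hardly moved, a 1.8-fold lower number from compound 2 to compound 3 (0.26 log units; within the scatter). Compound 4 carries a benzamido group of the same size class, so the expected step of a 1.5-fold higher number from compound 3 to compound 4 (0.19 log units; within the scatter) is small, in either direction, with no change beyond the scatter anticipated. For compound 4 the estimate in this assay is 2500 nM, with a range from 700 nM to 9000 nM.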

Compound 4, half-maximal effective concentration: 158 nM
Compound 4: the middle estimate sits 16-fold (1.20 log units) above what was measured, outside the stated range (below it).
By their numbers in this assay, from the lowest: compound 1; then compound 4; then compounds 3 and 2 (each within the scatter of the next).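

In this assay, the saturated ring carbon proves sensitive to how its aromatic ring is attached, which the near-equal numbers of compound 2 and compound 3 had not shown: benzamido in place of benzylcarbamoyl gives a 19-fold lower number from compound 2 to compound 4 (1.27 log units; beyond the scatter) and benzamido in place of the pyrazolylethoxy group, with the same number of heavy atoms, gives a 10-fold lower number from compound 3 to compound 4 (1.01 log units; beyond the scatter) as a second large step. An aromatic ring at this position therefore does not by itself go with a high number, although the step of a 2.5-fold higher number from compound 1 to compound 4 (0.41 log units; beyond the scatter) shows that cyclopentyloxy still needs less compound than benzamido. Nothing available here accounts for either large step.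

On these data alone, whether the amide hydrogen of benzamido contributes to this result stays open. So does how an amine, a carboxylic acid or a chloro-substituted benzamido group would read at this carbon.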